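Swapping pentafluorosulfanyl for trifluoromethyl on a shared core

A few compounds are considered here, and "the series" means these few. Any claim that something is new, unique, unknown or untested is made for them only; others in the source may bear on it.

Of the compounds shown here, three built on one shared core have been tested in an assay on mitochondria from L6 cells (Rattus norvegicus) for activation, with a stated time of 90 min; a lower number here means that less compound is needed, a higher number that more compound is needed for the effect. Compound 1, with structure `Oc1nc2nonc2nc1Nc1ccc(S(F)(F)(F)(F)F)cc1`, gives 3900 nM in this assay and stands second highest of the three numbers. Compound 2, `CCCCc1ccc(Nc2nc3nonc3nc2O)c(F)c1`, gives 1100 nM, a value beyond the usual scatter below that of compound 1. Compound 3, `Cc1ccc(C(F)(F)F)cc1Nc1nc2nonc2nc1O`, gives 32800 nM, well above compound 1 and also beyond the scatter.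

The next compound, compound 4 with structure `Oc1nc2nonc2nc1Nc1ccc(C(F)(F)F)cc1`, has not yet been measured in this assay. It differs from compound 1 in one place: a group of 4 heavy atoms (1 carbon, 3 fluorine; no ring) in place of a group of 6 heavy atoms (5 fluorine, 1 sulfur; no ring), on an aromatic carbon. For the measured compounds named here, no measured pair differs by exactly this change, so the size of the step can only be guessed. The smaller group that enters is related in kind to the one that leaves, and a moderate rise in the number, somewhat beyond the scatter, is expected: the step from compound 1 to compound 4 is estimated as a 2.1-fold higher number from compound 1 to compound 4 (0.31 log units; beyond the scatter). For compound 4 the expected value in this assay is 8000 nM, with a likely range from 2500 nM to 25000 nM.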

Compound 4, half-maximal effective concentration: 10400 nM
Beside the measured number, compound 4's estimate is 1.3-fold (0.11 log units) below it; measured number inside the range.
By their numbers in this assay, from the lowest: compound 2; then compound 1; then compound 4; then compound 3.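

For the compounds shown here, this is the first pair in the set that differs in one place only, so the group on this aromatic carbon can now be judged on its own. In this assay putting trifluoromethyl in place of pentafluorosulfanyl gives a 2.7-fold higher number from compound 1 to compound 4 (0.43 log units; beyond the scatter) and so, although modest, the step shows that this position responds even to a change between two fluorine-bearing groups with no ring. No measurement here accounts for the shift, so its cause remains unknown.

Still open, as far as these compounds go, is how this position would respond to a group of another kind, such as an amine, a carboxylic acid or a longer chain. A single step also cannot show whether the same swap would shift the number similarly on a compound with other substituents on the ring.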